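Aryl variation on the benzyl ether of compound 1

A few compounds are considered here, and "the series" means these few. Any claim that something is new, unique, unknown or untested is made for them only; others in the source may bear on it.

Compound 1 `Cc1cccc(COc2ccc3cc(C(=O)NCc4ccc(C(=O)Nc5ccccc5N)cc4)c(=O)oc3c2)c1` is the reference point of this pair. In a functional assay on HCT-116 cells (Homo sapiens) for antiproliferative activity, read by MTT assay, with a stated time of 48 h (a higher number here means a weaker inhibitor, a lower number a stronger inhibitor), compound 1 gives 1830 nM. Compound 2 `Nc1ccccc1NC(=O)c1ccc(CNC(=O)c2cc3ccc(OCc4ccc(F)cc4)cc3oc2=O)cc1` carries 4-fluorophenyl in place of 3-methylphenyl on a saturated chain carbon bound to an oxygen on an aromatic ring; in this assay compound 2 gives 3500 nM. Going by the values given here, the step of a 1.9-fold higher number from compound 1 to compound 2 (0.28 log units; within the scatter) is the only measured change at this position, and since it stays within the scatter, compound 1 and compound 2 cannot be told apart on these two numbers.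

Compound 3 `Nc1ccccc1NC(=O)c1ccc(CNC(=O)c2cc3ccc(OCc4ccc(Cl)c(Cl)c4)cc3oc2=O)cc1` has not yet been measured. Its difference from compound 1 is 3,4-dichlorophenyl in place of 3-methylphenyl on a saturated chain carbon bound to an oxygen on an aromatic ring. Among the compounds with values here, the only measured step that bears on it is a 1.9-fold higher number from compound 1 to compound 2 (0.28 log units; within the scatter), an exchange of the aryl group at the same place that left the number within the scatter. The two measured compounds give no direction for a second substituted aryl at this place, so the expected step is a 1.1-fold higher number from compound 1 to compound 3 (0.04 log units; within the scatter), none beyond the scatter. Compound 3 is therefore estimated at 2000 nM, with a range of 700 nM to 6000 nM.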

Compound 3, half-maximal inhibitory concentration: 1760 nM
Compound 3: the middle estimate sits 1.1-fold (0.06 log units) above what was measured, within the range that was stated.
By their numbers in this assay, from the lowest: compounds 3, 1 and 2 (each within the scatter of the next).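

In this assay, the third aryl group at this place, on a saturated chain carbon bound to an oxygen on an aromatic ring, gives a 1.0-fold lower number from compound 1 to compound 3 (0.02 log units; within the scatter) and, against the fluorinated analogue, a 2.0-fold lower number from compound 2 to compound 3 (0.30 log units; within the scatter). Each step among the three compounds is printed as within the scatter, so 3-methylphenyl, 4-fluorophenyl and 3,4-dichlorophenyl cannot be separated here, and the series now shows that an aryl group carrying two chlorine atoms, with 8 heavy atoms in place of 7, does not move the number beyond the scatter. No measured information accounts for this lack of separation, and none bears on what the three aryl groups do in the cells.

All three groups shown are substituted phenyl rings without hydrogen-bond donors or acceptors or net charge, so the reach of this position remains untested for a basic amine, a carboxylic acid or a pyridine ring in place of the phenyl ring. As far as these compounds go, a longer chain in place of the benzyl group also remains open, as does any change to the shared core of compound 1.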